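Capping one hydroxy group: compound 2 to compound 4

The source may hold more compounds than are shown below. What is called first, only, known or untested is meant among the compounds shown, and "the series" means these compounds.

compound 1 `CCOc1cc(-c2ccccc2)nc2ccccc12` gives 6 ug/mL
compound 2 `Oc1ccc2nc(-c3ccccc3)cc(O)c2c1` gives 2.86 ug/mL
compound 3 `Oc1ccc2c(O)cc(-c3ccccc3)nc2c1` gives 0.81 ug/mL

These three values all come from a functional assay on P388 cells (Mus musculus) for cytotoxicity (a higher number here means that more compound is needed for the effect, a lower number that less compound is needed), and form a modest series. Compound 2 gives 2.86 ug/mL and stands second highest of the three numbers. Compound 1 gives 6 ug/mL and compound 3 gives 0.81 ug/mL, and both gaps to compound 2 are beyond the scatter.

Compound 4 `COc1ccc2nc(-c3ccccc3)cc(O)c2c1` keeps the core of compound 2 and changes a single group, from hydroxy to methoxy. It has methyl in place of hydrogen on an oxygen on an aromatic ring. For the measured compounds named here, no pair of measured compounds isolates this change, so the data give no direct size for it. The whole series reaches only from compound 3 at 0.81 ug/mL to compound 1 at 6 ug/mL and this sets a modest scale for what one small change might do. In this assay a small step toward a higher number is therefore expected, quite possibly none beyond the scatter. The estimate amounts to an expected 1.3-fold higher number from compound 2 to compound 4 (0.10 log units; within the scatter) in this read-out. For compound 4 the estimated value is 3.6 ug/mL (expected range 1.3 ug/mL to 10 ug/mL)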

Compound 4, half-maximal effective concentration: 0.33 ug/mL
For compound 4 the middle estimate is 11-fold (1.04 log units) above the measured one; the measured number lies below the stated range.
By their numbers in this assay, from the lowest: compound 4; then compound 3; then compound 2; then compound 1.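

In this assay, for the compounds shown here, the change from hydroxy to methoxy, with methyl in place of hydrogen on an oxygen on an aromatic ring, gives an 8.7-fold lower number from compound 2 to compound 4 (0.94 log units; beyond the scatter) and thus the first size for any single change, since the earlier compounds included no pair differing in one place. It shows that the hydrogen on this oxygen can give way to methyl without any loss in this read-out, and that less compound is needed for the effect once the methyl is present. The other hydroxy group of compound 2 stays unchanged in compound 4, so the step speaks only for this one oxygen, and nothing available gives a reason for its size.

From the compounds shown here alone, whether the gain continues with a longer chain on this oxygen, such as propyl, or depends on the oxygen itself, as an amine at the same place could show, remains open. Also open, going by these compounds, is whether methyl on the remaining hydroxy group would give a step of similar size, since this single pair cannot settle how general the effect is.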